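A Third Aryl Variant at the Aromatic Nitrogen

This account rests on a few compounds, and the source may have more. Where it says the series, first, only, none or still open, it means among the compounds named here.

Two close relatives share a core and differ only in the aryl group on an aromatic nitrogen. Compound 1 `N#CC1=C(N)Oc2c(N)cc3nc4ccccc4nc3c2C12C(=O)N(Cc1cnnn1-c1c(F)cccc1F)c1ccccc12` carries a 2,6-difluorophenyl group there. In a functional assay on MCF7 cells (Homo sapiens) for antiproliferative activity, read by MTT assay, with a stated time of 48 h (on this read-out higher numbers stand for weaker inhibition and lower numbers for stronger inhibition), compound 1 gives only a limit of > 50000 nM. Compound 2 `N#CC1=C(N)Oc2c(N)cc3nc4ccccc4nc3c2C12C(=O)N(Cc1cnnn1-c1ccc(Cl)cc1Cl)c1ccccc12` bears a 2,4-dichlorophenyl group in the same position. In this assay compound 2 also gives only a limit, > 50000 nM. The step that the two limits leave unreadable from compound 1 to compound 2 therefore has no readable size. This is where compound 2 stands: at the limit of > 50000 nM in this assay, at which 2 of the 2 values shown sit, with no number of its own.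

Compound 3 `Cc1ccc(-n2nncc2CN2C(=O)C3(C(C#N)=C(N)Oc4c(N)cc5nc6ccccc6nc5c43)c3ccccc32)cc1Cl` changes the same position once more: 3-chloro-4-methylphenyl in place of 2,4-dichlorophenyl on an aromatic nitrogen. For the measured compounds named here, the only measured step that bears on this change, a step that the two limits leave unreadable from compound 1 to compound 2, cannot be read, so nothing supports expecting a move in either direction beyond the scatter. The expected step of a number no higher from compound 2 to compound 3 (the limit leaves the size open) is accordingly set to none. Compound 3 is expected to give about 50000 nM in this assay, with a range from 20000 nM to 100000 nM, and most probably only a limit again.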

Compound 3, half-maximal inhibitory concentration: > 50000 nM
Compound 3 was reported as a limit (the forecaster's own chance of this, stated with the estimate: 80%); the middle value sits exactly at the limit.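

No step among compound 1, compound 2 and compound 3 can be read, since each of them is reported in this assay only as a limit: the limit of > 50000 nM in this assay, at which 3 of the 3 values shown sit.

The compounds shown leave open whether these three aryl groups differ at all in this assay, as none of the compounds has a number of its own.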